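From dimethylamino to diethylamino on the amide chain

This account rests on a few compounds, and the source may have more. Where it says the series, first, only, none or still open, it means among the compounds named here.

Measured so far in a functional assay on PC-3 cells (Homo sapiens), read by MTT assay, with a stated time of 48 h; a higher number here means a weaker inhibitor, a lower number a stronger inhibitor:
- compound 1 (`CCn1c(C(=O)NCCN(C)C)ccc1C(CC)(CC)c1ccc(OCC(=O)C(C)(C)C)c(C)c1`) gives 2300 nM 
- compound 2 (`CCn1c(C(=O)NCCCN(C)C)ccc1C(CC)(CC)c1ccc(OCC(=O)C(C)(C)C)c(C)c1`) gives 1600 nM 

Compound 2, at 1600 nM, stands level with compound 1 at 2300 nM, since the two values lie within the scatter of each other, and neither can be ranked above the other. Compound 3 (`CCN(CC)CCCNC(=O)c1ccc(C(CC)(CC)c2ccc(OCC(=O)C(C)(C)C)c(C)c2)n1CC`) keeps the core and the chain of compound 2 and differs from it by one change: diethylamino in place of dimethylamino on a saturated chain carbon, three bonds along the chain from an amide-type nitrogen. In words, diethylamino stands in place of dimethylamino on a saturated chain carbon, three bonds along the chain from an amide-type nitrogen.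

For the measured compounds named here, no measured step makes this exchange. The nearest evidence is the chain change in the same region, a 1.4-fold lower number from compound 1 to compound 2 (0.16 log units; within the scatter), and it bears only indirectly. With so little to go on, no shift in either direction beyond the scatter is expected in this assay. The estimated step is a 1.1-fold lower number from compound 2 to compound 3 (0.03 log units; within the scatter), and this is an expectation only. The expected value for compound 3 is 1500 nM (estimated range 650 nM to 3500 nM) .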

Compound 3, half-maximal inhibitory concentration: 1800 nM
For compound 3 the middle estimate is 1.2-fold (0.08 log units) below the measured one; low and high end bracket the measured number.
By their numbers in this assay, from the lowest: compounds 2, 3 and 1 (each within the scatter of the next).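

In this assay, the exchange of dimethylamino for diethylamino, on a saturated chain carbon, three bonds along the chain from an amide-type nitrogen, gives a 1.1-fold higher number from compound 2 to compound 3 (0.05 log units; within the scatter). Unlike the earlier step, which altered the chain, this one alters the groups carried on the amine nitrogen, and it adds to the picture that the terminal amine tolerates this change without a shift beyond the scatter. The change of (diethylamino)methyl in place of dimethylamino, on a saturated chain carbon, two bonds along the chain from an amide-type nitrogen, gives a 1.3-fold lower number from compound 1 to compound 3 (0.11 log units; within the scatter), so compound 1, compound 2 and compound 3 cannot be ranked against one another, and no evidence at hand bears on this result.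

The compounds shown leave open whether a ring amine such as piperidine or morpholine, or a primary amine, would move the number beyond the scatter at this place. They also leave open what a longer chain, or a carboxylic acid in place of the amine, would do in this assay.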